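The source may report more compounds than this note shows. Statements on the series, on what has been measured and on what is new or still open speak of the compounds shown alone.

Three compounds share one core and differ only at two outer positions. Compound 1 `N=C(NS(=O)(=O)c1ccc(Cl)cc1)N1CCN(c2cc3c(cc2F)c(=O)c(C(=O)O)cn3C2CC2)CC1` is measured in a functional assay on HL-60 cells (Homo sapiens) for antiproliferative activity, read by MTT assay, with a stated time of 72 h (on this read-out lower numbers stand for stronger inhibition and higher numbers for weaker inhibition), where compound 1 gives 43 nM. Compound 2 `CCn1cc(C(=O)O)c(=O)c2cc(F)c(N3CCN(C(=N)NS(=O)(=O)c4ccccc4Cl)CC3)cc21` gives 43 nM in this assay, and compound 3 `CCn1cc(C(=O)O)c(=O)c2cc(F)c(N3CCN(C(=N)NS(=O)(=O)c4ccc(Cl)cc4)CC3)cc21` gives 43 nM. Compound 1 thus stands level with compounds 2 and 3: its nearest neighbour is compound 2 and its furthest is compound 3, yet neither gap reaches beyond the scatter. Two single changes have been measured. Putting ethyl in place of cyclopropyl on an aromatic nitrogen gave no change at the digits printed from compound 1 to compound 3 (within the scatter). Putting 4-chlorophenyl in place of 2-chlorophenyl on a sulfonyl sulfur gave no change at the digits printed from compound 2 to compound 3 (within the scatter).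

Compound 4 `N=C(NS(=O)(=O)c1cccc(Cl)c1)N1CCN(c2cc3c(cc2F)c(=O)c(C(=O)O)cn3C2CC2)CC1` has not been measured. It differs from compound 1 in one place: 3-chlorophenyl in place of 4-chlorophenyl on a sulfonyl sulfur. Among the compounds with values here, the step that bears on this is the one from compound 2 to compound 3, where the chlorine on the phenyl group on the sulfonyl sulfur was likewise placed differently and the read-out did not shift beyond the scatter. A third placement need not behave the same, yet nothing among these compounds points otherwise. Compound 4 is therefore expected to sit close to compound 1, an expected step of no change at the digits printed from compound 1 to compound 4 (within the scatter). In this assay compound 4 is estimated at 43 nM, with a range from 20 nM to 90 nM.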

Compound 4, half-maximal inhibitory concentration: 43 nM
For compound 4 middle estimate and measured number coincide at the digits printed; the measured number falls inside the stated range.
By their numbers in this assay, from the lowest: compounds 1, 2, 3 and 4 (each within the scatter of the next).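

In this assay, putting 3-chlorophenyl in place of 4-chlorophenyl on a sulfonyl sulfur gave no change at the digits printed from compound 1 to compound 4 (within the scatter). The earlier step that moved the chlorine belonged to compounds with ethyl on the aromatic nitrogen, so this result adds a further chlorine placement and shows the same flat outcome with cyclopropyl there instead. Among the compounds shown, then, the read-out does not respond to where the chlorine sits on this phenyl group, but nothing here explains that flat result.

All of these compounds keep a chlorine on this phenyl group, so it remains open whether the read-out would stay level with a methoxy group, an amine or a carboxylic acid in its place, or with a longer chain in place of the whole phenyl group. From the compounds shown here alone, it is also open whether the flat result reflects real indifference at this position or something shared by the compounds, since the identical values say nothing about how far this tolerance extends.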